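Cyclohexyl in Place of Cyclopentyloxy on a Shared Core

A few compounds are considered here, and "the series" means these few. Any claim that something is new, unique, unknown or untested is made for them only; others in the source may bear on it.

Compound 1 `Cc1cccc(N2CCN(c3cc(C(F)(F)F)ccc3CNC(=O)C(C)c3ccc(NS(C)(=O)=O)c(F)c3)CC2)c1`: 1.8 nM
Compound 2 `CC(C(=O)NCc1ccc(C(F)(F)F)cc1OC1CCCC1)c1ccc(NS(C)(=O)=O)c(F)c1`: 0.6 nM
Compound 3 `C[C@H](C(=O)NCc1ccc(C(F)(F)F)cc1SC1CCCCC1)c1ccc(NS(C)(=O)=O)c(F)c1`: 0.3 nM

All three were measured in an assay on CHO cells for antagonist activity at transient receptor potential cation channel subfamily V member 1 (Homo sapiens), read by FLIPR; a higher number here means a weaker inhibitor, a lower number a stronger inhibitor. Compound 2 gives the second highest of the three numbers; compound 3 lies nearest to it, within the scatter of repeated measurements, while compound 1 lies furthest away with a higher number, beyond the scatter. Compound 4 `CC(C(=O)NCc1ccc(C(F)(F)F)cc1C1CCCCC1)c1ccc(NS(C)(=O)=O)c(F)c1` has not yet been measured. It differs from compound 2 in one place: cyclohexyl in place of cyclopentyloxy on an aromatic carbon. Within the data shown here, no measured pair shows this exact change. Compound 3 also carries a cyclohexyl ring and in this assay compound 3 gives 0.3 nM, close to compound 2. On that basis the expected step is a 1.2-fold lower number from compound 2 to compound 4 (0.08 log units; within the scatter), not beyond the scatter. Compound 4 is expected to give 0.5 nM, with a range from 0.15 nM to 2 nM.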

Compound 4, inhibition constant: 0.6 nM
Compound 4: middle estimate off by 1.2-fold (0.08 log units), on the low side; low and high end bracket the measured number.
By their numbers in this assay, from the lowest: compounds 3, 2 and 4 (each within the scatter of the next); then compound 1.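

In this assay, cyclohexyl in place of cyclopentyloxy on this aromatic carbon gives no change at the digits printed from compound 2 to compound 4 (within the scatter). At this position, then, a ring joined directly to the aromatic carbon reads the same as a ring joined through oxygen, even though the group's one hydrogen-bond acceptor is gone and its ring is six-membered rather than five-membered. No measurement on hand explains this result. Still open, on these data alone, is how a cyclopentyl or cyclohexyloxy group would read here, which would separate the oxygen from the ring size. Also open, as far as these compounds go, is how an amine at this carbon would read.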